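Oxamide Enantiomers: Turning the Stereocentre From R to S

A few compounds are considered here, and "the series" means these few. Any claim that something is new, unique, unknown or untested is made for them only; others in the source may bear on it.

The series is tested in a functional assay on the whole organism (strain Wistar albino) for inhibition, with Rattus norvegicus as the target, read by paw edema, in the formalin test, with a stated time of 1 h, at a dose of 20 mg/kg by the oral route; on this read-out higher numbers stand for more inhibition at the one dose given (going by the name of the read-out) and lower numbers for less inhibition. Compound 1, `N#Cc1cnn(-c2ccccc2)c1NC(=O)C(=O)Nc1c(C#N)cnn1-c1ccccc1`, gives 44% in this assay. Compound 2, `CC(NC(=O)C(=O)Nc1c(C#N)cnn1-c1ccccc1)c1ccccc1`, gives 38%. Compound 3, `C[C@@H](NC(=O)C(=O)Nc1c(C#N)cnn1-c1ccccc1)c1ccccc1`, gives 33%, the lowest of the three numbers, though its gap to compound 2 is within the scatter and only its gap to compound 1 lies beyond it.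

Compound 4, `C[C@H](NC(=O)C(=O)Nc1c(C#N)cnn1-c1ccccc1)c1ccccc1`, differs from compound 3 in that (the two compounds have the same atoms and bonds and differ only in configuration as drawn: 1 of 1 stereo elements differ; a stereocentre at a saturated chain carbon is drawn R in compound 3 and S in compound 4). Among the measured compounds shown here, the one measured step that bears on this is a number 5 percentage points lower from compound 2 to compound 3 (within the scatter), and it concerns the same stereocentre, because of the fact that one of compounds 2 and 3 is drawn with a defined configuration and the other without, at the place where they differ. Since compound 2 carries that centre undefined and compound 3 carries it as R, a mixture-to-single-isomer step that stays within the scatter gives no sign that the configuration matters much. The step from compound 3 to compound 4 is therefore expected to be small, a number 9 percentage points higher from compound 3 to compound 4 (within the scatter), and in no sure direction. Compound 4 is estimated at 42%, with a range from 30% to 54%.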

Compound 4, a percentage reported as inhibition, in the whole organism at one dose (the size of the read-out at that dose, not a potency): 35%
Compound 4: middle estimate off by 7 percentage points, on the high side; the measured number falls inside the stated range.
By their numbers in this assay, from the lowest: compounds 3, 4, 2 and 1 (each within the scatter of the next, the first and the last beyond it).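

In this assay the R and S forms at the saturated chain carbon can now be set directly against each other, and turning the stereocentre from R to S gives only a step within the scatter (a number 2 percentage points higher from compound 3 to compound 4 (within the scatter)), in a comparison confined to that one centre: (the fact that compounds 3 and 4 differ only in the configuration as drawn). The S form also stands within the scatter of the compound drawn without a configuration (a number 3 percentage points lower from compound 2 to compound 4 (within the scatter)), as the R form did, in a comparison that again turns on this centre alone: (the fact that one of compounds 2 and 4 is drawn with a defined configuration and the other without, at the place where they differ). At this one dose, therefore, neither configuration can be told apart from the other or from the undefined form.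

The compounds shown leave open whether a longer chain or a carboxylic acid in place of the methyl group on that carbon would give a step beyond the scatter. They also leave open whether the two forms would stay this close at another dose.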